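Swapping a hydroxyl for bromine on the hydrazone aryl ring

This account rests on a few compounds, and the source may have more. Where it says the series, first, only, none or still open, it means among the compounds named here.

Compound 1 `O=C(COc1cccc2ccccc12)N/N=C/c1ccc(Cl)cc1`: 87.6 ug/mL
Compound 2 `O=C(COc1cccc2ccccc12)N/N=C/c1ccc(O)cc1`: 26.5 ug/mL
Compound 3 `O=C(COc1cccc2ccccc12)N/N=C/c1cccc(O)c1`: 32.6 ug/mL

All three share one core and differ only in the aryl ring attached to the carbon double-bonded to nitrogen. In an ADME assay on MT4 cells (Homo sapiens) for cytotoxicity, read by MTT assay, with a stated time of 4 days (a higher number here means that more compound is tolerated, a lower number that less compound is tolerated), compound 3 stands second highest; its nearest neighbour is compound 2, with a 1.2-fold higher number from compound 2 to compound 3 (0.09 log units; within the scatter), while compound 1 lies further off, with a 2.7-fold lower number from compound 1 to compound 3 (0.43 log units; beyond the scatter). Compound 4 `O=C(COc1cccc2ccccc12)N/N=C/c1ccccc1Br` carries 2-bromophenyl in place of 3-hydroxyphenyl on a carbon with a double bond to nitrogen. Because a 2.7-fold lower number from compound 1 to compound 3 (0.43 log units; beyond the scatter) lowered the number when a chloro-bearing ring gave way to a hydroxyl-bearing ring, and compound 4 reverses that kind of exchange, the number is expected to rise modestly, a 2.1-fold higher number from compound 3 to compound 4 (0.33 log units; beyond the scatter). Compound 4 is estimated at 70 ug/mL, within a range from 35 ug/mL to 140 ug/mL.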

Compound 4, half-maximal cytotoxic concentration: 11.4 ug/mL
Estimate against measurement, compound 4: 6.1-fold (0.79 log units) above, and the stated range ends above it.
By their numbers in this assay, from the lowest: compound 4; then compounds 2 and 3 (each within the scatter of the next); then compound 1.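

In this assay, a ring without hydroxyl does not by itself give a higher number: 2-bromophenyl sits below both hydroxyl-bearing rings, with a 2.9-fold lower number from compound 3 to compound 4 (0.46 log units; beyond the scatter) and a 2.3-fold lower number from compound 2 to compound 4 (0.37 log units; beyond the scatter) as the steps. Carrying a halogen does not settle the number at this carbon either, as the two halogen-bearing rings lie well apart, with a 7.7-fold lower number from compound 1 to compound 4 (0.89 log units; beyond the scatter) as the step. Nothing measured here accounts for these drops.

Compound 1 and compound 4 differ in both the halogen and its place on the ring, so the two remain tangled. A 2-chlorophenyl or 4-bromophenyl ring would separate them, and an aminophenyl ring would test a different kind of group.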